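The compounds below may be only part of what the source reports. "The series", "measured", "known", "first", "only" and "open" are said of these compounds alone.

Three measured compounds and one unmeasured compound share the same core and differ only in the group on an amine nitrogen in a ring. Compound 1 `O=C(CN1CCN(C2CCCCC2)CC1)Nc1nc2c(s1)CCCC2` carries cyclohexyl there. In an assay on isolated protein for inhibition of long-chain fatty acid transport protein 1 (Mus musculus), read by scintillation counting, with a stated time of 20 min (on this read-out higher numbers stand for weaker inhibition and lower numbers for stronger inhibition), compound 1 gives > 10000 nM, which is a limit of the assay and not a number. Compound 2 `O=C(CN1CCN(c2ccncc2)CC1)Nc1nc2c(s1)CCCC2` carries pyridin-4-yl. In this assay compound 2 gives > 10000 nM, again a limit rather than a number. Among the measured compounds shown here, compound 3 `O=C(CN1CCN(c2ccccn2)CC1)Nc1nc2c(s1)CCCC2` carries pyridin-2-yl, and in this assay compound 3 gives 4900 nM, the only true number among the three. Compound 1 and compound 2 both sit at the limit of > 10000 nM in this assay, at which 2 of the 3 values shown sit. The steps of an at least 2.0-fold lower number from compound 1 to compound 3 (0.30 log units; that floor lies within the scatter) and an at least 2.0-fold lower number from compound 2 to compound 3 (0.30 log units; that floor lies within the scatter) therefore have floors that lie within the usual scatter, while a step that the two limits leave unreadable from compound 1 to compound 2 cannot be read at all.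

Compound 4 `O=C(CN1CCN(c2ccc(F)cc2)CC1)Nc1nc2c(s1)CCCC2` is not yet measured. It differs from compound 3 by 4-fluorophenyl in place of pyridin-2-yl on an amine nitrogen in a ring. For the measured compounds named here, no measured step exchanges pyridin-2-yl for a carbon-only aromatic ring, so the measured steps show only that compound 3 is the one that gave a readable number. In this assay the step of a 1.6-fold higher number from compound 3 to compound 4 (0.21 log units; within the scatter) is expected to be small or unreadable, with a real chance that compound 4 returns only a limit. Compound 4 is estimated at 8000 nM, with a range from 2500 nM to 25000 nM.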

Compound 4, half-maximal inhibitory concentration: 4000 nM
Compound 4: the middle estimate sits 2.0-fold (0.30 log units) above what was measured; measured number inside the range.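

In this assay the change to 4-fluorophenyl gives a 1.2-fold lower number from compound 3 to compound 4 (0.09 log units; within the scatter), so the two groups cannot be told apart, and a readable number at this position does not depend on the ring nitrogen of pyridin-2-yl. Set against the other two groups, 4-fluorophenyl gives an at least 2.5-fold lower number from compound 2 to compound 4 (0.39 log units; beyond the scatter) and an at least 2.5-fold lower number from compound 1 to compound 4 (0.39 log units; beyond the scatter), and both clear the scatter where the floors for compound 3 did not, though they remain floors rather than true sizes because their starting compounds return no number: the limit of > 10000 nM in this assay, at which 2 of the 4 values shown sit. An aromatic ring alone is still not enough, since compound 2, which also carries one, gives > 10000 nM, a limit of the assay and not a number.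

What the fluorine contributes stays open, as plain phenyl and 4-chlorophenyl are not among the compounds shown. Also open, from the compounds shown here alone, is whether any other group on this ring nitrogen, such as a benzyl or a 4-methoxyphenyl, could give a number clearly lower than those of compound 3 and compound 4, or whether that would take a change elsewhere on the shared core.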